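Ester series: shortening the acyl group

The source may hold more compounds than are shown below. What is called first, only, known or untested is meant among the compounds shown, and "the series" means these compounds.

compound 1 `CC(C)=CC1C(C(=O)OCC2COCCOCCOCCOCCOCCO2)C1(C)C`: 54000 nM
compound 2 `O=C(CCCCOc1ccccc1)OCC1COCCOCCOCCOCCOCCO1`: > 100000 nM

In a functional assay on SW1573 cells (Homo sapiens) for inhibition, read by sulforhodamine B assay, with a stated time of 48 h (a higher number here means a weaker inhibitor of growth, a lower number a stronger inhibitor of growth), compound 1 gives 54000 nM. For compound 2 only a limit of the assay is known, > 100000 nM. The single measured step, an at least 1.8-fold higher number from compound 1 to compound 2 (0.26 log units; that floor lies within the scatter), runs into the limit of > 100000 nM in this assay, at which 1 of the 2 values shown sits, and is therefore only a floor; compound 2 stands at the top of the numbers shown, with no fixed value. Compound 3 `CC(=O)OCC1COCCOCCOCCOCCOCCO1` differs from compound 2 by hydrogen in place of 3-phenoxypropyl on a saturated chain carbon bound to a carbonyl carbon. Going by the values given here, no measured step removes a chain at this place, and the one step known is bounded by a limit, so little can be read across. Compound 3 is expected near 150000 nM (range 40000 nM to 500000 nM), an estimated step that the limit leaves unreadable from compound 2 to compound 3 that is not expected to reach beyond the scatter.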

Compound 3, concentration for 50% growth inhibition: > 100000 nM
Compound 3: only a limit was reported; the forecaster's own chance of this, stated with the estimate: 70%; the middle value is on the limit's open side.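

Compound 3 gives only a limit in this assay, > 100000 nM. With methyl on the carbonyl carbon, the result is an at least 1.8-fold higher number from compound 1 to compound 3 (0.26 log units; that floor lies within the scatter), so a second, much smaller acyl group also yields no fixed value. The steps between compound 2 and compound 3 cannot be read, and the loss of 3-phenoxypropyl has no measurable size at this place; two of the three compounds now end at the same ceiling: the limit of > 100000 nM in this assay, at which 2 of the 3 values shown sit.

Going by these compounds alone, compound 1 remains the only fixed value. From the compounds shown here alone, whether an amine, a carboxylic acid or a longer alkyl chain on the carbonyl carbon would give a readable value stays open.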